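The source may hold more compounds than are shown below. What is called first, only, known or untested is meant among the compounds shown, and "the series" means these compounds.

Measured compounds:
- compound 1, `Cc1c(/C=C/[S+](C)[O-])oc2ccccc2c1=O`: 7200 nM
- compound 2, `Cc1cccc2c(=O)cc(/C=C/[S+](C)[O-])oc12`: 6800 nM
- compound 3, `C[S+]([O-])/C=C/c1cc(=O)c2cc(F)ccc2o1`: 7000 nM

Of the compounds shown here, three sharing the same core have been tested in a functional assay on DLD-1 cells (Homo sapiens) for cytotoxicity, with a stated time of 48 h; on this read-out higher numbers stand for weaker inhibition and lower numbers for stronger inhibition. Compound 1 gives 7200 nM and compound 2 gives 6800 nM in this assay, while compound 3 gives 7000 nM. The three numbers lie within the usual scatter of one another, so no order among them can be read; compound 3 stands second highest of the three, with compound 1 closest and compound 2 furthest, both gaps well inside the scatter.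

Compound 4, `CC(C)CC(=O)Oc1ccc2oc(/C=C/[S+](C)[O-])cc(=O)c2c1`, has not yet been measured in this assay. It differs from compound 3 as follows: (isobutylcarbonyl)oxy in place of fluoro on an aromatic carbon.

Within the data shown here, no step between measured compounds that changes a single site is available, so the expectation rests only on the narrow spread of the three values. Because the values of compound 1 at 7200 nM and compound 2 at 6800 nM sit so close to that of compound 3, a step from compound 3 to compound 4 of no change at the digits printed from compound 3 to compound 4 (within the scatter) is expected, that is, none beyond the scatter. Compound 4 is therefore estimated at 7000 nM, within a range from 3000 nM to 16000 nM.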

Compound 4, half-maximal inhibitory concentration: 6100 nM
Beside the measured number, compound 4's estimate is 1.1-fold (0.06 log units) above it; low and high end bracket the measured number.
By their numbers in this assay, from the lowest: compounds 4, 2, 3 and 1 (each within the scatter of the next).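

In this assay, among these compounds, the exchange of fluoro for (isobutylcarbonyl)oxy on this aromatic carbon gives a 1.1-fold lower number from compound 3 to compound 4 (0.06 log units; within the scatter), and this is the first step that changes a single site. Among the compounds shown here, the earlier compounds showed only that three differently substituted members gave close numbers, whereas this pair shows that this one change, from a single fluorine to a group of seven heavy atoms with two hydrogen-bond acceptors, leaves the read-out within the scatter. No measurement among those shown accounts for this result.

On these data alone, whether an amine, a carboxylic acid or a longer chain on this same carbon would move the number beyond the scatter remains open. Also open, as far as these compounds go, is whether (isobutylcarbonyl)oxy would behave the same way alongside the methyl groups of compound 1 or compound 2.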